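Swapping the five-membered ring on a shared core

The compounds below may be only part of what the source reports. "The series", "measured", "known", "first", "only" and "open" are said of these compounds alone.

Three compounds share one core and differ only in what sits on a saturated chain carbon bound to an oxygen next to a carbonyl group: compound 1 `COC(=O)C1=C(C)NC(=S)NC1c1ccoc1`, compound 2 `CCCOC(=O)C1=C(C)NC(=S)NC1c1ccoc1` and compound 3 `CC1=C(C(=O)OCc2ccccc2)C(c2ccoc2)NC(=S)N1`. In an assay on membranes from HeLa cells for displacement of a labelled ligand from adenosine receptor A3 (Homo sapiens), read by scintillation counting, with a stated time of 180 min, tested at 1 uM (a higher number here means more inhibition at the concentration tested (going by the name of the read-out), a lower number less inhibition), compound 1 gives 3%, compound 2 gives 3% and compound 3 gives 20%. Compound 2 therefore stands level with compound 1, the two together the lowest of the three numbers, as the step of no change at the digits printed from compound 1 to compound 2 (within the scatter) shows. Only the phenyl lifts the read-out: a number 17 percentage points higher from compound 2 to compound 3 (beyond the scatter), and likewise a number 17 percentage points higher from compound 1 to compound 3 (beyond the scatter).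

Compound 4 `CCCOC(=O)C1=C(C)NC(=S)NC1c1cccs1` keeps the propoxycarbonyl group of compound 2 and alters the five-membered ring: thiophen-2-yl in place of furan-3-yl on a saturated ring carbon. Furan-3-yl leaves and thiophen-2-yl enters. None of the three measured steps touches this ring; all of them alter the chain on the oxygen, so they give no direct guide. What they do show is that compounds 1 and 2 sit at the bottom of the range and that a modest rise came only with the phenyl. The ring swap is expected to give a step of a number 3 percentage points higher from compound 2 to compound 4 (within the scatter), nothing beyond the scatter. Compound 4 is estimated at 6%, within a range from 0% to 22%.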

Compound 4, a percentage reported as inhibition, at one concentration (the size of the read-out at that concentration, not a potency): 10%
The estimate for compound 4 lay 4 percentage points below the measured number; low and high end bracket the measured number.
By their numbers in this assay, from the lowest: compounds 1, 2, 4 and 3 (each within the scatter of the next, the first and the last beyond it).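

Among these compounds, until now only the chain on the oxygen had varied, and compound 4 is the first to alter the five-membered ring on the saturated ring carbon: thiophen-2-yl in place of furan-3-yl gives a number 7 percentage points higher from compound 2 to compound 4 (within the scatter). In this assay, this position therefore accepts this one swap with no step beyond the scatter, although two things differ at once, the hetero atom (sulfur for oxygen) and the point at which the ring is attached, and a single pair cannot tell these apart. Nothing available explains the result, whether through a measured property or through any other data on these compounds.

Still open, going by these compounds, is whether this position responds at all to a group of another kind, such as an amine or a carboxylic acid carried on the five-membered ring, and whether furan-2-yl or thiophen-3-yl would separate the effect of the hetero atom from that of the attachment point. On these data alone, it is also open what thiophen-2-yl would give when paired with the phenyl-bearing chain of compound 3, the only chain so far to give a step beyond the scatter.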